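Swapping the Five-Membered Ring on the Side Chain

This account rests on a few compounds, and the source may have more. Where it says the series, first, only, none or still open, it means among the compounds named here.

Of the compounds shown here, three built on one shared core have been tested in an assay on CHO cells for displacement of a labelled ligand from prostaglandin E2 receptor EP3 subtype (Homo sapiens), read by radioligand binding; on this read-out lower numbers stand for stronger inhibition and higher numbers for weaker inhibition. Compound 1 `CC(C)C(Cc1ncc[nH]1)c1ccc(-c2ccc3cccc(F)c3c2)[nH]c1=O` gives 11 nM, compound 2 `CC(C)C(c1ccc(-c2ccc3cccc(F)c3c2)[nH]c1=O)N1CCCCC1=O` gives 6.4 nM, and compound 3 `Cc1nc(C(c2ccc(-c3ccc4cccc(F)c4c3)[nH]c2=O)C(C)C)[nH]c1C` gives 7 nM. Compound 3 thus stands second highest of these three numbers; its steps to the others, a 1.6-fold lower number from compound 1 to compound 3 (0.20 log units; within the scatter) and a 1.1-fold higher number from compound 2 to compound 3 (0.04 log units; within the scatter), stay within the scatter, as does a 1.7-fold lower number from compound 1 to compound 2 (0.24 log units; within the scatter). Compound 4 `CC(C)C(Cc1noc(=O)[nH]1)c1ccc(-c2ccc3cccc(F)c3c2)[nH]c1=O` is not yet measured; the change is a group of 7 heavy atoms (3 carbon, 2 nitrogen, 2 oxygen; one five-membered aromatic ring with 3 hetero atoms) in place of a group of 7 heavy atoms (5 carbon, 2 nitrogen; one five-membered aromatic ring with 2 hetero atoms), on a saturated chain carbon bound to an aromatic carbon and a saturated chain carbon. Every exchange so far on that saturated chain carbon left the number within the scatter, so the expected step is a 1.4-fold higher number from compound 3 to compound 4 (0.15 log units; within the scatter), none beyond the scatter. The estimate for compound 4 in this assay is 10 nM, with a range from 4 nM to 25 nM.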

Compound 4, inhibition constant: 34 nM
The estimate for compound 4 lay 3.4-fold (0.53 log units) below the measured number; the measured number lies above the stated range.
By their numbers in this assay, from the lowest: compounds 2, 3 and 1 (each within the scatter of the next); then compound 4.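

For the compounds shown here, this position does not accept every group equally in this assay: the five-membered aromatic ring with 3 hetero atoms gives the first steps beyond the scatter, with a 4.9-fold higher number from compound 3 to compound 4 (0.69 log units; beyond the scatter), a 5.3-fold higher number from compound 2 to compound 4 (0.73 log units; beyond the scatter) and a 3.1-fold higher number from compound 1 to compound 4 (0.49 log units; beyond the scatter). The 4,5-dimethyl-1H-imidazol-2-yl group and its replacement in compound 4 each count 7 heavy atoms, so heavy-atom count alone does not separate them. Nothing available here explains the shift. From the compounds shown here alone, whether a carboxylic acid or a tetrazole on this saturated chain carbon would track compound 4 remains open.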